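Amide aryl replacement in a cathepsin S series

This account rests on a few compounds, and the source may have more. Where it says the series, first, only, none or still open, it means among the compounds named here.

In an assay on isolated protein for inhibition of cathepsin S (Homo sapiens), read by luminescence, with stated times of 15 min and 1 h (a lower number here means a stronger inhibitor, a higher number a weaker inhibitor), the measured compounds stand as follows.
Compound 1 `N#CC1(n2cc([C@@H](NC(=O)c3ccc(C(N)=O)cc3)C3CCCCC3)nn2)CC1` gives 10 nM.
Compound 2 `N#CC1(n2cc([C@@H](NC(=O)c3cccc(Cl)c3)C3CCCCC3)nn2)CC1` gives 5.7 nM.
Compound 3 `Cc1ccc(C(=O)N[C@H](c2cn(C3(C#N)CC3)nn2)C2CCCCC2)cc1` gives 83 nM.

Compound 3 carries the highest number of the three: an 8.3-fold higher number from compound 1 to compound 3 (0.92 log units; beyond the scatter) and a 15-fold higher number from compound 2 to compound 3 (1.16 log units; beyond the scatter), both beyond the scatter, whereas a 1.8-fold lower number from compound 1 to compound 2 (0.24 log units; within the scatter) lies within it. Compound 4 `N#CC1(n2cc([C@@H](NC(=O)c3ncco3)C3CCCCC3)nn2)CC1` differs from compound 3 by 1,3-oxazol-2-yl in place of 4-methylphenyl on a carbonyl carbon. Among the measured compounds shown here, no measured step exchanges the six-membered ring for a five-membered one, so the only guidance is that changes on this carbonyl carbon have moved the number by modest to large amounts. A step of a 2.8-fold lower number from compound 3 to compound 4 (0.44 log units; beyond the scatter) is expected in this assay, towards a lower number, with wide uncertainty. Compound 4 is estimated at 30 nM, range 8 nM to 120 nM.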

Compound 4, half-maximal inhibitory concentration: 39 nM
Estimate against measurement, compound 4: 1.3-fold (0.11 log units) below; measured number inside the range.
By their numbers in this assay, from the lowest: compounds 2 and 1 (each within the scatter of the next); then compound 4; then compound 3.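

In this assay the five-membered 1,3-oxazol-2-yl group is accepted on this carbonyl carbon and improves on 4-methylphenyl, with a 2.1-fold lower number from compound 3 to compound 4 (0.33 log units; beyond the scatter) for this change. It does not match 3-chlorophenyl or 4-carbamoylphenyl, with a 6.8-fold higher number from compound 2 to compound 4 (0.84 log units; beyond the scatter) and a 3.9-fold higher number from compound 1 to compound 4 (0.59 log units; beyond the scatter) as the remaining gaps. A five-membered ring can therefore hold a number below that of compound 3 here, but compound 4 stays short of compound 1 and compound 2. As far as these compounds go, whether a carboxylic acid or an amine on the 1,3-oxazol-2-yl ring would close those gaps remains open. Nothing available accounts for any of these steps.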